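Tail changes on the shared core: cytotoxicity notes

A few compounds are considered here, and "the series" means these few. Any claim that something is new, unique, unknown or untested is made for them only; others in the source may bear on it.

In an ADME assay on RAW264.7 cells (Mus musculus) for cytotoxicity, read by MTT assay, with a stated time of 72 h, tested at 50 uM (a lower number here means less inhibition, a higher number more inhibition at the concentration tested (going by the name of the read-out)), compound 3 `CC(c1ccccc1)N1CCN(CC(=O)N2CCN(c3cc4c(cc3F)c(=O)c(C(=O)O)cn4C3CC3)CC2)CC1` gives 16.9%. Among the compounds with values here, on the numbers so far that is the highest of three, yet it sits within the scatter of both neighbours: compound 1 `CC(=O)N1CCN(CC(=O)N2CCN(c3cc4c(cc3F)c(=O)c(C(=O)O)cn4C3CC3)CC2)CC1` gives 16.2% in this assay, and compound 2 `O=C(O)c1cn(C2CC2)c2cc(N3CCN(C(=O)CN4CCN(c5ccccc5Cl)CC4)CC3)c(F)cc2c1=O` gives 14.9%. The three measured steps, a number 1.3 percentage points lower from compound 1 to compound 2 (within the scatter), a number 0.7 percentage points higher from compound 1 to compound 3 (within the scatter) and a number 2 percentage points higher from compound 2 to compound 3 (within the scatter), each lie within the scatter, so exchanging acetyl, 2-chlorophenyl and 1-phenylethyl on the amine nitrogen in a ring has not moved the read-out.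

Compound 4 `CCN1CCN(CC(=O)N2CCN(c3cc4c(cc3F)c(=O)c(C(=O)O)cn4C3CC3)CC2)CC1` is reached from compound 3 by hydrogen in place of phenyl on a saturated chain carbon bound to an amine nitrogen in a ring and a saturated chain carbon. Within the data shown here, the steps that bear on it are the two that alter the same distal group, namely a number 0.7 percentage points higher from compound 1 to compound 3 (within the scatter) and a number 2 percentage points higher from compound 2 to compound 3 (within the scatter), both small. Nothing in the set suggests a change beyond the scatter in this assay, so compound 4 is expected to give about 16%, between 8% and 24%. The expected step is a number 0.9 percentage points lower from compound 3 to compound 4 (within the scatter).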

Compound 4, a percentage reported as inhibition, at one concentration (the size of the read-out at that concentration, not a potency): 13.3%
For compound 4 the middle estimate is 2.7 percentage points above the measured one, and the stated range covers the measured number.
By their numbers in this assay, from the lowest: compounds 4, 2, 1 and 3 (each within the scatter of the next).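

Taking the phenyl off the saturated chain carbon, which turns 1-phenylethyl into ethyl, gives a number 3.6 percentage points lower from compound 3 to compound 4 (within the scatter) in this assay, so this position also accommodates a plain alkyl tail with neither an aromatic ring nor a carbonyl without a change beyond the scatter. Ethyl in place of the other two tails reads the same way, with a number 1.6 percentage points lower from compound 2 to compound 4 (within the scatter) and a number 2.9 percentage points lower from compound 1 to compound 4 (within the scatter), which leaves all four tails on the shared core within the scatter of one another. No supporting measurement bears on this flat result.

From the compounds shown here alone, whether a tail carrying a carboxylic acid or a primary amine, or a chain longer than ethyl, would stay equally flat remains open. Also open, going by these compounds, is whether the four tails would still read alike in a full concentration series rather than at the single concentration tested.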